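The source may hold more compounds than are shown below. What is called first, only, known or untested is meant among the compounds shown, and "the series" means these compounds.

Compound 2 `O=C(Nc1cccc(-n2cc(-c3ccncc3)c(-c3ccc(Cl)c(O)c3)n2)c1)Nc1ccc(Cl)c(Cl)c1` is one of two measured compounds built on the same core. In a functional assay on MDA-MB-468 cells (Homo sapiens) for inhibition, read by sulforhodamine B assay, with a stated time of 48 h (a lower number here means that less compound is tolerated, a higher number that more compound is tolerated), compound 2 gives only a limit, > 32500 nM. Its partner compound 1 `COc1cc(-c2nn(-c3cccc(NC(=O)Nc4ccc(Cl)c(Cl)c4)c3)cc2-c2ccncc2)ccc1Cl` is likewise known only as a limit: in this assay compound 1 gives > 50000 nM. Among the measured compounds shown here, the single step between them, a step that the two limits leave unreadable from compound 1 to compound 2, stays unreadable, since the two limits the limit of > 32500 nM in this assay, at which 1 of the 2 values shown sits, and the limit of > 50000 nM in this assay, at which 1 of the 2 values shown sits, leave no number to compare. Compound 3 `O=C(Nc1cccc(-n2cc(-c3ccncc3)c(-c3ccc(Cl)c(O)c3)n2)c1)Nc1ccc(Cl)c(C(F)(F)F)c1` is the next member and has not yet been measured. It differs from compound 2 by trifluoromethyl in place of chloro on an aromatic carbon. For the measured compounds named here, no measured step bears on that change, and with compound 2 resting at a limit no size or direction beyond the scatter can be read from what is known. Compound 3 is therefore expected to sit near the same limit, estimated at 40000 nM with a range from 10000 nM to 100000 nM. The step this estimate means, a step that the limit leaves unreadable from compound 2 to compound 3, is expected to be small.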

Compound 3, concentration lethal to 50% of the cells: > 32500 nM
Compound 3 was reported as a limit (the forecaster's own chance of this, stated with the estimate: 70%); the middle value is on the limit's open side.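

Compound 2 and compound 3 are both known in this assay only as limits, so no step can be read between them: the limit of > 32500 nM in this assay, at which 2 of the 3 values shown sit. The compounds shown leave open whether trifluoromethyl in place of chloro on an aromatic carbon changes the result in this assay at all.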